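Compound 4: replacing furan-2-yl on a carbonyl carbon

The compounds below may be only part of what the source reports. "The series", "measured", "known", "first", "only" and "open" are said of these compounds alone.

compound 1 `Cc1ccc(C(=O)OC2CCC(CN3CCN(c4cc(=O)c5cc(C(F)(F)F)cc([N+](=O)[O-])c5s4)CC3)CC2)cc1`: 9.7%
compound 2 `CC(=O)OC1CCC(CN2CCN(c3cc(=O)c4cc(C(F)(F)F)cc([N+](=O)[O-])c4s3)CC2)CC1`: 0%
compound 3 `O=C(OC1CCC(CN2CCN(c3cc(=O)c4cc(C(F)(F)F)cc([N+](=O)[O-])c4s3)CC2)CC1)c1ccco1`: 1%

These three compounds were tested in an ADME assay on cells (Hepatocyte, Homo sapiens) for metabolic stability, with a stated time of 30 min; on this read-out higher numbers stand for a more stable compound and lower numbers for a less stable compound. Compound 3 gives 1%, a value within the scatter of those of the other two, so it holds no distinct rank among them.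

Compound 4 `O=C(OC1CCC(CN2CCN(c3cc(=O)c4cc(C(F)(F)F)cc([N+](=O)[O-])c4s3)CC2)CC1)c1ccc(C(F)(F)F)cc1` differs from compound 3 as follows: 4-(trifluoromethyl)phenyl in place of furan-2-yl on a carbonyl carbon. Among the compounds with values here, three measured steps bear on this change, all made on the same carbonyl carbon. Putting methyl in place of 4-methylphenyl gives a number 9.7 percentage points lower from compound 1 to compound 2 (within the scatter). Putting furan-2-yl in place of 4-methylphenyl gives a number 8.7 percentage points lower from compound 1 to compound 3 (within the scatter). Putting furan-2-yl in place of methyl gives a number 1 percentage points higher from compound 2 to compound 3 (within the scatter). None of these steps leaves the scatter, and none involves 4-(trifluoromethyl)phenyl itself.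

The nearest measured comparison is compound 1, which carries 4-methylphenyl and gives 9.7%. No change beyond the scatter is therefore expected, only a small upward drift at most. The expected step is a number 5 percentage points higher from compound 3 to compound 4 (within the scatter). Compound 4 is estimated at 6%, with an expected range from 0% to 18%.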

Compound 4, percent of the compound remaining: 5.2%
Compound 4: the middle estimate sits 0.8 percentage points above what was measured, and the stated range covers the measured number.
By their numbers in this assay, from the lowest: compounds 2, 3, 4 and 1 (each within the scatter of the next).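

In this assay, 4-(trifluoromethyl)phenyl on this carbonyl carbon adds a further aromatic group to the series, and its steps from the two groups with the lowest values remain small: furan-2-yl gives way to it with a number 4.2 percentage points higher from compound 3 to compound 4 (within the scatter), and methyl gives way to it with a number 5.2 percentage points higher from compound 2 to compound 4 (within the scatter). The new compound also provides a change on the aromatic ring itself, since trifluoromethyl in place of methyl on an aromatic carbon gives a number 4.5 percentage points lower from compound 1 to compound 4 (within the scatter), so neither the substituent on the phenyl ring nor the swap of the whole group moves the read-out beyond the scatter in these compounds. Nothing given here explains the values or the size of these steps.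

The four compounds therefore do not separate methyl, furan-2-yl, 4-methylphenyl and 4-(trifluoromethyl)phenyl in this assay, and they do not show whether any group on this carbonyl carbon could lift the read-out clear of the scatter. As far as these compounds go, it remains open what an amine or a carboxylic acid on the aromatic ring, a longer chain on the carbonyl carbon, or a nitrogen in place of the oxygen next to a carbonyl group would do.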